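Urea series: stereochemistry and aryl substituent in a whole-organism read-out

The source may hold more compounds than are shown below. What is called first, only, known or untested is meant among the compounds shown, and "the series" means these compounds.

Compound 1 `Cc1ccccc1NC(=O)N[C@@H](C)c1ccccc1` gives 100% in an ADME assay on the whole organism with Oryza sativa as the target, tested at 0.1 uM; a lower number here means a stronger effect, a higher number a weaker effect of the compound at the concentration tested.
Compound 2 `CCCc1ccc(NC(=O)N[C@H](C)c2ccccc2)cc1` gives 33% in this assay.
Compound 3 `CCCc1ccc(NC(=O)N[C@@H](C)c2ccccc2)cc1` gives 97% in this assay.

Compound 3 stands second highest of the three values in this assay, within the scatter of compound 1 and far above compound 2. Within the data shown here, the only single-point step measured so far is a number 64 percentage points higher from compound 2 to compound 3 (beyond the scatter), which is large and rests on the fact that compounds 2 and 3 differ only in the configuration as drawn alone.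

Compound 4 `C[C@H](NC(=O)Nc1ccc(F)cc1)c1ccccc1` differs from compound 3 by fluoro in place of propyl on an aromatic carbon. Among the measured compounds shown here, no measured step touches this substituent; the configuration step between compound 2 and compound 3 does not bear on it. Compounds 1 and 3 carry different alkyl groups on the aryl ring and lie within the scatter of each other, which gives no sign of sensitivity to that position. Compound 4 is therefore expected to stay near compound 3, with a number 5 percentage points lower from compound 3 to compound 4 (within the scatter) not beyond the scatter. The estimate for compound 4 in this assay is 92%, ranging from 65% to 100%.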

Compound 4, a percentage reported as activity, at one concentration (the size of the read-out at that concentration, not a potency): 96%
Compound 4: the middle estimate sits 4 percentage points below what was measured, and the stated range covers the measured number.
By their numbers in this assay, from the lowest: compound 2; then compounds 4, 3 and 1 (each within the scatter of the next).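

In this assay, fluoro in place of propyl on this aromatic carbon gives a number 1 percentage points lower from compound 3 to compound 4 (within the scatter) and so leaves the read-out unchanged in this configuration. In that configuration, propyl and fluoro thus cannot be told apart at this position, and neither gives a stronger effect. Nothing at hand accounts for this step.

Going by these compounds, whether fluoro would behave the same way in the configuration of compound 2 remains open. So does the outcome with an amine or a carboxylic acid on this aromatic carbon.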